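Swapping 2-ethoxyphenyl for 3-methoxyphenyl on the amine nitrogen

The compounds below may be only part of what the source reports. "The series", "measured", "known", "first", "only" and "open" are said of these compounds alone.

Values so far in a functional assay on HeLa cells (Homo sapiens) for inhibition, read by sulforhodamine B assay; a higher number here means a weaker inhibitor, a lower number a stronger inhibitor

Compound 1 `O=C1C=C(Nc2ccccc2F)C(=O)c2c1nc1n2[C@H]2OC[C@@H](O)[C@H]2OC1` gives 5120 nM
Compound 2 `CCOc1ccccc1NC1=CC(=O)c2nc3n(c2C1=O)[C@H]1OC[C@@H](O)[C@H]1OC3` gives 6040 nM

Compound 2 lies within the usual scatter of compound 1, so these two numbers give no ranking. Among the compounds with values here, the one measured step shows a 1.2-fold higher number from compound 1 to compound 2 (0.07 log units; within the scatter) with ethoxy in place of fluoro on an aromatic carbon. Compound 3 `COc1cccc(NC2=CC(=O)c3nc4n(c3C2=O)[C@H]2OC[C@@H](O)[C@H]2OC4)c1` brings a new change: 3-methoxyphenyl in place of 2-ethoxyphenyl on an amine nitrogen with 3-methoxyphenyl in place of 2-ethoxyphenyl on an amine nitrogen. Within the data shown here, no measured compound carries 3-methoxyphenyl, and that leaves the one measured step as only a loose guide. Even so, it stayed within the scatter, so no step beyond the scatter is expected in this assay and neither direction is favoured. The expected step is a 1.1-fold lower number from compound 2 to compound 3 (0.04 log units; within the scatter) on this reasoning. For compound 3 the estimate is 5500 nM with 2000 nM to 15000 nM as its expected range.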

Compound 3, half-maximal inhibitory concentration: 4280 nM
Compound 3: the middle estimate sits 1.3-fold (0.11 log units) above what was measured; measured number inside the range.
By their numbers in this assay, from the lowest: compounds 3, 1 and 2 (each within the scatter of the next).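

In this assay, 3-methoxyphenyl on the amine nitrogen gives a 1.4-fold lower number from compound 2 to compound 3 (0.15 log units; within the scatter) and a 1.2-fold lower number from compound 1 to compound 3 (0.08 log units; within the scatter), so 2-fluorophenyl, 2-ethoxyphenyl and 3-methoxyphenyl cannot be ranked at this position. This exchange alters both the chain on the ring and the numbered ring position at once, so the two changes cannot be separated, yet together they still produce no step beyond the scatter. No other measurement here helps to explain why these numbers stay so close.

As far as these compounds go, it remains open whether a group of a different kind on this nitrogen, such as a phenyl ring carrying a carboxylic acid or a saturated cyclohexyl ring, would move the number beyond the scatter. From the compounds shown here alone, all three compounds share one core, so what the core itself contributes also stays open.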